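Chlorobenzyl sulfanyl series: from compound 2 to compound 3

A few compounds are considered here, and "the series" means these few. Any claim that something is new, unique, unknown or untested is made for them only; others in the source may bear on it.

In a functional assay on the whole organism (artery, strain albino) with Rattus norvegicus as the target, with a stated time of 300 min, at a dose of 10 mg/kg by the oral route (a higher number here means more inhibition at the dose given (going by the name of the read-out), a lower number less inhibition), compound 1 `CC1=C(C(=O)Nc2ccc([N+](=O)[O-])cc2)C(c2ccc(Br)cc2)N=C(SCc2ccc(Cl)cc2)N1` gives 37.9%. Compound 2 `CC1=C(C(=O)Nc2ccc([N+](=O)[O-])cc2)C(c2cccc([N+](=O)[O-])c2)N=C(SCc2cccc(Cl)c2)N1` gives 21% in this assay, the lowest of the two numbers, with the gap to compound 1 beyond the scatter. Compound 3 `CC1=C(C(=O)Nc2ccc([N+](=O)[O-])cc2)C(c2cccc([N+](=O)[O-])c2)N=C(SCc2ccc(Cl)cc2)N1` differs from compound 2 by 4-chlorophenyl in place of 3-chlorophenyl on a saturated chain carbon bound to a sulfur. Going by the values given here, no single-change step between measured compounds covers this change. Compound 1 also carries a 4-chlorobenzyl group while differing elsewhere, and its 37.9% is only a loose pointer. A small upward step, within the scatter, is expected: a number 6 percentage points higher from compound 2 to compound 3 (within the scatter). Compound 3 is estimated at 27%, range 12% to 42%.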

Compound 3, a percentage reported as inhibition, in the whole organism at one dose (the size of the read-out at that dose, not a potency): 24.1%
The estimate for compound 3 lay 2.9 percentage points above the measured number, within the range that was stated.
By their numbers in this assay, from the lowest: compounds 2 and 3 (each within the scatter of the next); then compound 1.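

In this assay, 4-chlorophenyl in place of 3-chlorophenyl on a saturated chain carbon bound to a sulfur gives a number 3.1 percentage points higher from compound 2 to compound 3 (within the scatter), so this exchange does not stand out from the scatter with 3-nitrophenyl on the saturated ring carbon. Going by these compounds alone, with the 4-chlorobenzyl group held constant, 3-nitrophenyl in place of 4-bromophenyl on that ring carbon gives a number 13.8 percentage points lower from compound 1 to compound 3 (beyond the scatter), the only step here beyond the scatter. No supporting data bear on either step.

From the compounds shown here alone, whether the chlorine exchange behaves alike with 4-bromophenyl on the ring carbon remains open. So does the outcome with an amine or a carboxylic acid in place of chlorine on the benzyl group.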